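The source may report more compounds than this note shows. Statements on the series, on what has been measured and on what is new or still open speak of the compounds shown alone.

Of the compounds shown here, three built on one shared core have been measured in an ADME assay on microsomes from liver (Homo sapiens) for metabolic stability, read by LC-MS, using NADPH, tested at 5 uM; a lower number here means that the compound disappears faster, a higher number that the compound lasts longer. Compound 1 `Cc1cccc(CSc2cc(Cl)c(C)cc2S(=O)(=O)/N=C(\N)n2nccc2-c2ccccc2)c1` gives a half-life of 0.232 h. Compound 3 `Cc1cc(S(=O)(=O)/N=C(\N)n2nccc2-c2ccccc2)c(SCc2cccc(Cl)c2)cc1Cl` gives 0.309 h. Compound 2 `Cc1ccc(CSc2cc(Cl)c(C)cc2S(=O)(=O)/N=C(\N)n2nc(C)cc2-c2ccccc2)cc1` gives 0.176 h, the lowest of the three numbers, yet its gaps to the other two stay within the usual scatter, so the three compounds cannot be ranked on these numbers.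

The step of interest leads from compound 2 to compound 4 `Cc1cc(-c2ccccc2)n(/C(N)=N/S(=O)(=O)c2cc(C)c(Cl)cc2SCc2ccccc2)n1`, which has not yet been measured. The change is hydrogen in place of methyl on an aromatic carbon.

For the measured compounds named here, only one measured step touches a single aromatic substituent: a 1.3-fold higher number from compound 1 to compound 3 (0.12 log units; within the scatter). That step is a change of one small group on the same ring for another, and it moved the number by less than the scatter. Going by the values given here, no measured pair shows a methyl being replaced by hydrogen, so the expectation for compound 4 rests on the observation that all three measured numbers lie close together and that the one single-point change seen so far made no clear difference.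

The expected outcome for compound 4 is therefore a step of a 1.1-fold higher number from compound 2 to compound 4 (0.06 log units; within the scatter), that is, no change beyond the scatter. Compound 4 is estimated at 0.2 h, within a range from 0.1 h to 0.4 h.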

Compound 4, half-life: 0.0938 h
Compound 4: middle estimate off by 2.1-fold (0.33 log units), on the high side; the whole stated range lies above it.
By their numbers in this assay, from the lowest: compounds 4, 2, 1 and 3 (each within the scatter of the next, the first and the last beyond it).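

Going from 4-methylbenzyl to benzyl, with hydrogen in place of methyl on an aromatic carbon of a six-membered aromatic ring of carbon only, para to a large group, gives in this assay a 1.9-fold lower number from compound 2 to compound 4 (0.27 log units; within the scatter) and is the first measured pair to isolate this methyl. The earlier compounds shown here offered only a swap of one small group for another, whereas this pair shows the outcome of taking a methyl away altogether, and the step still stays within the usual scatter, so these two numbers give no firm sign that this methyl matters for how long the compound lasts. No measurement offered here accounts for the number seen with compound 4, so the result stands without an explanation.

The compounds shown leave open how a methoxy group, a fluorine atom, an amine or a carboxylic acid in this same place would compare with the hydrogen of compound 4 and the methyl of compound 2. They also leave open whether the same swap would give a similar step on a different version of the shared core.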